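A few compounds are considered here, and "the series" means these few. Any claim that something is new, unique, unknown or untested is made for them only; others in the source may bear on it.

Compound 2 `O=C(C[C@@H](CCCC1CCCCC1)c1nc(C(=O)N2CCCCC2)no1)NO` gives 26 nM in an assay on CHO cells for inhibition of bone morphogenetic protein 1 (Homo sapiens), read by fluorescence; on this read-out higher numbers stand for weaker inhibition and lower numbers for stronger inhibition. Among the measured compounds shown here, its only measured neighbour, compound 1 `CNC(=O)c1noc([C@H](CCCC2CCCCC2)CC(=O)NO)n1`, gives 28 nM in this assay, and the step of a 1.1-fold lower number from compound 1 to compound 2 (0.03 log units; within the scatter) lies within the scatter, so the two compounds cannot be told apart on these numbers. Compound 3 `CN1CCN(CN(C)C(=O)c2noc([C@H](CCCC3CCCCC3)CC(=O)NO)n2)CC1` differs from compound 2 by methyl((4-methylpiperazin-1-yl)methyl)amino in place of piperidin-1-yl on a carbonyl carbon. For the measured compounds named here, the single measured step that bears on this position is the one from compound 1 to compound 2, where the amide substituent was changed without any shift beyond the scatter. The group entering in compound 3 is larger and carries more hetero atoms than either of those, so the earlier step is only a partial guide, but it suggests that this carbonyl substituent is tolerated. Compound 3 is therefore expected to stay close to compound 2, with the step of a 1.3-fold higher number from compound 2 to compound 3 (0.13 log units; within the scatter) estimated to be no more than a modest one. The estimated value for compound 3 in this assay is 35 nM, with a range from 12 nM to 110 nM.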

Compound 3, half-maximal inhibitory concentration: 54 nM
Beside the measured number, compound 3's estimate is 1.5-fold (0.19 log units) below it; low and high end bracket the measured number.
By their numbers in this assay, from the lowest: compounds 2, 1 and 3 (each within the scatter of the next, the first and the last beyond it).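

In this assay the carbonyl substituent now gives its first step beyond the scatter, (a 2.1-fold higher number from compound 2 to compound 3 (0.32 log units; beyond the scatter)), a modest one, with methyl((4-methylpiperazin-1-yl)methyl)amino in place of piperidin-1-yl on a carbonyl carbon. The comparison with the smaller amide reads differently: (4-methylpiperazin-1-yl)methyl in place of hydrogen on an amide-type nitrogen gives (a 1.9-fold higher number from compound 1 to compound 3 (0.29 log units; within the scatter)), so this much larger group is accommodated with little penalty, and the position's tolerance, suggested only by a step among smaller groups, now extends to it. Nothing available accounts for the modest shift.

The compounds shown leave open how a morpholine amide or a dimethylamino group would read on this carbonyl carbon. They also leave open whether a carboxylic acid in place of the amide would hold the number.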